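Replacing 4-chlorophenyl with cyclopropyl on the sulfonyl sulfur

The source may report more compounds than this note shows. Statements on the series, on what has been measured and on what is new or still open speak of the compounds shown alone.

In an ADME assay (liver) for metabolic stability, with Liver microsome (Homo sapiens) as the target, read by LC-MS, using microsomes and NADPH, with a stated time of 5 min, at 37 degrees C (a lower number here means slower removal, a higher number faster removal of the compound), compound 1 (`CCn1c([C@@H](C)NS(=O)(=O)c2ccc(Cl)cc2)nc2ccc(C(F)(F)F)cc21`) gives > 100 mL.min-1.g-1 as its reading, which is a limit of the assay and not a number. Compound 2 (`CCn1c([C@@H](C)NS(=O)(=O)c2ccc(Cl)cc2)nc2ccc(CN(C)C)cc21`) gives 30 mL.min-1.g-1 in the same test. That measured step, an at least 3.3-fold lower number from compound 1 to compound 2 (0.52 log units; beyond the scatter), changes another group, so it bears only indirectly, showing that one change can bring compound 1 off (the limit of > 100 mL.min-1.g-1 in this assay, at which 1 of the 2 values shown sits). Compound 3 (`CCn1c([C@@H](C)NS(=O)(=O)C2CC2)nc2ccc(C(F)(F)F)cc21`) differs from compound 1 as follows: cyclopropyl in place of 4-chlorophenyl on a sulfonyl sulfur. A modest fall is expected, with an estimated at least 1.6-fold lower number from compound 1 to compound 3 (0.22 log units; that floor lies within the scatter) in this assay as its size. Compound 3 is expected at 60 mL.min-1.g-1 (25 mL.min-1.g-1 to 130 mL.min-1.g-1).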

Compound 3, intrinsic clearance in microsomes: < 3 mL.min-1.g-1
Compound 3 gave a limit, no number; the forecaster's own chance of this, stated with the estimate: 30%; at least 20-fold (1.30 log units) between middle value and limit.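

The group on the sulfonyl sulfur proves to be a second place that moves the reading in this assay, with an at least 33-fold lower number from compound 1 to compound 3 (1.52 log units; beyond the scatter) for cyclopropyl in place of 4-chlorophenyl. Compound 3 gives < 3 mL.min-1.g-1, which is a limit of the assay and not a number. Compound 1 gives > 100 mL.min-1.g-1, also a limit, so the step sets only a floor on the size of the change.

From the compounds shown here alone, the true reading of compound 3 stays open. So does whether an open chain such as ethyl, or an amine, on the sulfonyl sulfur would read as cyclopropyl does.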